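The source may report more compounds than this note shows. Statements on the series, on what has been measured and on what is new or still open speak of the compounds shown alone.

Measured in a functional assay on Gurav cells (Homo sapiens) for inhibition, read by sulforhodamine B assay; on this read-out lower numbers stand for stronger inhibition of growth and higher numbers for weaker inhibition of growth:
compound 1 `Oc1ccc(-c2ccc(-c3ccc(-c4nc5ccccc5[nH]4)cc3)cc2)cc1` gives 100000 nM
compound 2 `Cc1ccc2[nH]c(-c3ccc(-c4ccc(-c5ccc(OC(F)(F)F)cc5)cc4)cc3)nc2c1` gives 11000 nM

Compound 2 holds the lower of the two numbers in this assay, and its gap to compound 1 lies beyond the usual scatter. Compound 3 `Cc1ccc2[nH]c(-c3ccc(-c4ccc(-c5ccc(O)cc5)cc4)cc3)nc2c1` has not yet been measured. It differs from compound 2 by hydrogen in place of trifluoromethyl on an oxygen on an aromatic ring, so that 4-(trifluoromethoxy)phenyl becomes 4-hydroxyphenyl (hydrogen in place of trifluoromethyl on an oxygen on an aromatic ring). Among the measured compounds shown here, no measured pair shows this change alone. For the measured compounds named here, compound 1, the one measured compound carrying 4-hydroxyphenyl, gives 100000 nM, which points towards a higher number, meaning weaker inhibition of growth, by a step beyond the scatter. The expected change is a 3.6-fold higher number from compound 2 to compound 3 (0.56 log units; beyond the scatter). For compound 3 the estimate is 40000 nM, with an expected range from 12000 nM to 100000 nM.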

Compound 3, concentration for 50% growth inhibition: 11300 nM
Estimate against measurement, compound 3: 3.5-fold (0.55 log units) above; measured number below the stated range.
By their numbers in this assay, from the lowest: compounds 2 and 3 (each within the scatter of the next); then compound 1.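

In this assay the change from 4-(trifluoromethoxy)phenyl to 4-hydroxyphenyl, hydrogen in place of trifluoromethyl on an oxygen on an aromatic ring, gives (a 1.0-fold higher number from compound 2 to compound 3 (0.01 log units; within the scatter)), so the read-out does not separate these two groups here. The gap that compound 1 showed is thus not tied to the 4-hydroxyphenyl group, since with that group held constant, methyl in place of hydrogen on an aromatic carbon gives (an 8.8-fold lower number from compound 1 to compound 3 (0.95 log units; beyond the scatter)). No measurement shown bears on why either step has the size it has.

The compounds shown leave open whether a methyl or a longer chain on that oxygen, or an amine in its place, would stay level with compound 2 and compound 3. They also leave open whether chlorine or ethyl in place of that methyl would hold the step from compound 1.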